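Aromatic substituent restored on the carbon that bore methoxy

The compounds below may be only part of what the source reports. "The series", "measured", "known", "first", "only" and "open" are said of these compounds alone.

The three measured compounds share one core and differ only in the group on an aromatic carbon of that core. Compound 1 `Nc1ccccc1NC(=O)C1(S(=O)(=O)c2ccc(Oc3ccc(OC(F)(F)F)cc3)cc2)CCC2(CCNCC2)C1` gives 900 nM in a functional assay on blood (Homo sapiens), with a stated time of 60 min, in the presence of a further agent that is not named here; on this read-out lower numbers stand for an effect already at smaller amounts and higher numbers for an effect only at larger amounts of compound. Compound 2 `Nc1ccc(-c2ccccc2)cc1NC(=O)C1(S(=O)(=O)c2ccc(Oc3ccc(OC(F)(F)F)cc3)cc2)CCC2(CCNCC2)C1` carries a phenyl on that aromatic carbon, and in this assay compound 2 reaches only a limit of <= 400 nM (the limit of <= 400 nM in this assay, at which 1 of the 3 values shown sits). Compound 3 `COc1ccc(N)c(NC(=O)C2(S(=O)(=O)c3ccc(Oc4ccc(OC(F)(F)F)cc4)cc3)CCC3(CCNCC3)C2)c1` carries a methoxy on the same aromatic carbon, and in this assay compound 3 gives 3700 nM, the highest of the two numbers shown. The measured steps are an at least 2.2-fold lower number from compound 1 to compound 2 (0.35 log units; beyond the scatter), a 4.1-fold higher number from compound 1 to compound 3 (0.61 log units; beyond the scatter) and an at least 9.2-fold higher number from compound 2 to compound 3 (0.96 log units; beyond the scatter).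

Among the measured compounds shown here, compound 4 `Cc1ccc(-c2ccc(N)c(NC(=O)C3(S(=O)(=O)c4ccc(Oc5ccc(OC(F)(F)F)cc5)cc4)CCC4(CCNCC4)C3)c2)o1` has not yet been measured. 5-methylfuran-2-yl in place of methoxy on an aromatic carbon The steps that bear on this change are the two that alter the same aromatic carbon: phenyl in place of hydrogen gave a lower number, and methoxy in place of phenyl gave a clearly higher one. Since 5-methylfuran-2-yl is again an aromatic ring, compound 4 is expected to move back toward compound 2, with an expected step of a 9.3-fold lower number from compound 3 to compound 4 (0.97 log units; beyond the scatter). Compound 4 is therefore estimated at 400 nM in this assay, within a range from 150 nM to 1200 nM.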

Compound 4, half-maximal effective concentration: > 15000 nM
Compound 4: only a limit was reported; the forecaster's own chance of this, stated with the estimate: 40%; middle value at least 37-fold (1.57 log units) from the limit.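

Compound 4 in this assay is reported only as a limit of the assay, not as a number: the limit of > 15000 nM in this assay, at which 1 of the 4 values shown sits. Even so, the result shows that an aromatic ring on this carbon does not by itself carry the effect seen with phenyl, since replacing methoxy with 5-methylfuran-2-yl gives an at least 4.0-fold higher number from compound 3 to compound 4 (0.60 log units; beyond the scatter), and replacing phenyl with it gives an at least 37-fold higher number from compound 2 to compound 4 (1.57 log units; beyond the scatter). Measured against hydrogen on the same carbon, the change gives an at least 16-fold higher number from compound 1 to compound 4 (1.22 log units; beyond the scatter), so phenyl and 5-methylfuran-2-yl move the read-out in opposite directions from compound 1, and this position separates the two rings sharply.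

On these data alone, what a plain furan-2-yl or a thiophene ring would give on this carbon stays open, so the contributions of the furan ring and its methyl group cannot be told apart. The true distance between compound 2 and compound 4 also stays open, since each is known only as a limit, and the compounds shown give no cause for the difference.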